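The source may hold more compounds than are shown below. What is called first, only, known or untested is meant among the compounds shown, and "the series" means these compounds.

Measured compounds, with their values in a toxicity assay on Huh-7.5 cells (Homo sapiens) for inhibition, read by MTT assay, with a stated time of 96 h; on this read-out lower numbers stand for higher toxicity in this test and higher numbers for lower toxicity in this test:

compound 1 `CN1CCN(Cc2ccc(NC(=O)c3ccc(OCCCCl)c(S(N)(=O)=O)c3)cc2C(F)(F)F)CC1`: 5470 nM
compound 2 `CCC(=O)Nc1cc(C(=O)Nc2ccc(OC)cc2)ccc1OC`: 109000 nM
compound 3 `CN1CCN(Cc2ccc(NC(=O)c3ccc(OCCCCCl)c([N+](=O)[O-])c3)cc2C(F)(F)F)CC1`: 3740 nM

Compound 1 stands second highest of the three numbers in this assay. Its nearest neighbour is compound 3, whose value of 3740 nM lies within the scatter of compound 1, so no order between the two can be read from these data. The furthest is compound 2, which at 109000 nM sits well beyond the scatter on the less toxic side; compound 2 does not share the core of compound 1, so its number says little about the step considered here.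

The unmeasured compound 4 `CN1CCN(Cc2ccc(NC(=O)c3ccc(OCCCCl)c(F)c3)cc2C(F)(F)F)CC1` differs from compound 1 in one place: fluoro in place of sulfamoyl on an aromatic carbon. Among the measured compounds shown here, no step between two measured compounds describes this kind of change, so the expectation can rest only on the general closeness of compound 1 and compound 3 in this assay.

Given that compound 1 gives 5470 nM and compound 3 gives 3740 nM, the step from compound 1 to compound 4 is expected to be small, most likely within the scatter and, if anything, slightly toward lower numbers: a 1.4-fold lower number from compound 1 to compound 4 (0.14 log units; within the scatter).

Compound 4 is therefore estimated at 4000 nM in this assay, with a likely range from 1500 nM to 12000 nM.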

Compound 4, half-maximal cytotoxic concentration: 8800 nM
Compound 4: the middle estimate sits 2.2-fold (0.34 log units) below what was measured; the range from low to high includes it.
By their numbers in this assay, from the lowest: compounds 3, 1 and 4 (each within the scatter of the next, the first and the last beyond it); then compound 2.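

In this assay, putting fluoro in place of sulfamoyl on the aromatic carbon ortho to a 3-chloropropoxy group gives a 1.6-fold higher number from compound 1 to compound 4 (0.21 log units; within the scatter), so this pair cannot be told apart on this read-out. This is the first step shown at this position with the rest of the structure held constant, and here the hydrogen-bond donor and acceptors of sulfamoyl leave without a change that can be read beyond the scatter. This single pair is the only information on the position, and no measurement shown here accounts for the closeness of the two numbers.

Still open, on these data alone, is whether the same closeness would hold for other groups on this carbon, such as an amine, a carboxylic acid or a nitrile, since one pair cannot show whether the position is generally insensitive in this test. Also open, as far as these compounds go, is whether the sulfamoyl and fluoro pair would stay this close with a longer chain in place of the 3-chloropropoxy group, or with a hydroxyl at the end of that chain in place of the chlorine.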